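A few compounds are considered here, and "the series" means these few. Any claim that something is new, unique, unknown or untested is made for them only; others in the source may bear on it.

Compound 3 `Cc1ccnc(NC(c2ccccc2F)c2ccc3cccnc3c2O)c1` gives 880 nM in an assay for inhibition of protein disulfide-isomerase (Homo sapiens), with a stated time of 1 h (a lower number here means a stronger inhibitor, a higher number a weaker inhibitor), and so holds the second highest of the three numbers measured. Compound 2 `COc1ccc(C(Nc2cc(C)ccn2)c2ccc3cccnc3c2O)cc1O`, which differs from it only in the group on the saturated chain carbon bound to an aromatic carbon and a nitrogen on an aromatic ring, gives 150 nM in this assay, and compound 1 `Cc1ccnc(NC(c2ccc(C(F)(F)F)cc2)c2ccc3cccnc3c2O)c1` gives 26500 nM in this assay. The move from compound 3 to compound 4 `Cc1ccnc(NC(c2ccc(F)cc2)c2ccc3cccnc3c2O)c1` is 4-fluorophenyl in place of 2-fluorophenyl on a saturated chain carbon bound to an aromatic carbon and a nitrogen on an aromatic ring.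

Three measured steps change the group at this same place: a 180-fold lower number from compound 1 to compound 2 (2.25 log units; beyond the scatter), a 30-fold lower number from compound 1 to compound 3 (1.48 log units; beyond the scatter) and a 5.9-fold higher number from compound 2 to compound 3 (0.77 log units; beyond the scatter). Within the data shown here, they show that this position can move the number a long way, but none of them compares a 2-fluorophenyl with a 4-fluorophenyl, and the only other measured group carrying a substituent at the 4-position, the 4-(trifluoromethyl)phenyl of compound 1, differs from a fluorine in more than its position. The direction of the step in this assay is therefore uncertain, and the size is expected to be modest, possibly within the scatter.

Compound 4 is accordingly expected to give about 1500 nM in this assay, within a range from 400 nM to 6000 nM, which would be a step of a 1.7-fold higher number from compound 3 to compound 4 (0.23 log units; within the scatter).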

Compound 4, half-maximal inhibitory concentration: 140 nM
Beside the measured number, compound 4's estimate is 11-fold (1.03 log units) above it; measured number outside the range, below it.
By their numbers in this assay, from the lowest: compounds 4 and 2 (each within the scatter of the next); then compound 3; then compound 1.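

Moving one fluorine is not a neutral change at this place in this assay: a 6.3-fold lower number from compound 3 to compound 4 (0.80 log units; beyond the scatter) with 4-fluorophenyl in place of 2-fluorophenyl, although the two compounds have the same atoms. The large gap between the two groups carrying a substituent in the same printed position shows that the poor number of compound 1 cannot be read as a property of that position alone, since a 190-fold lower number from compound 1 to compound 4 (2.28 log units; beyond the scatter) with fluoro in place of trifluoromethyl on an aromatic carbon. The step of a 1.1-fold lower number from compound 2 to compound 4 (0.03 log units; within the scatter) lies within the scatter, so in this pair the ring with a single fluoro and the 3-hydroxy-4-methoxyphenyl ring cannot be told apart, and the hydroxy and methoxy groups of compound 2 are not needed to reach this level in this assay.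

The compounds shown leave open where a chloro or a methyl in place of the fluoro of compound 4 would fall on the wide span between compound 4 and compound 1. Nothing given here accounts for any of these steps.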